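A few compounds are considered here, and "the series" means these few. Any claim that something is new, unique, unknown or untested is made for them only; others in the source may bear on it.

Measured compounds:
compound 1 `Cc1ccc(/C=C/C(=O)c2sc(NC(=O)c3ccc(F)cc3)nc2C)cc1`, 91.5%
compound 2 `Cc1nc(NC(=O)c2ccccc2)sc1C(=O)/C=C/c1ccc(N(C)C)cc1`, 88.2%

In an assay for inhibition of Polyunsaturated fatty acid 5-lipoxygenase (Homo sapiens), read by spectrophotometry, tested at 10 uM, in the presence of a further agent that is not named here (a lower number here means less inhibition, a higher number more inhibition at the concentration tested (going by the name of the read-out)), compound 1 gives 91.5%, and compound 2 gives 88.2%. Compound 2 stands alongside compound 1 on these two numbers; their gap lies within the usual scatter, so neither can be set above the other. Compound 3 `Cc1nc(NC(=O)c2ccc(F)cc2)sc1C(=O)/C=C/c1ccc(N(C)C)cc1` differs from compound 2 by fluoro in place of hydrogen on an aromatic carbon. Going by the values given here, no step between two measured compounds follows this change alone, so the expected step from compound 2 to compound 3, a number 0.8 percentage points higher from compound 2 to compound 3 (within the scatter), is taken as none beyond the scatter. Compound 3 is therefore expected to give 89%, ranging from 78% to 97%.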

Compound 3, a percentage reported as inhibition, at one concentration (the size of the read-out at that concentration, not a potency): 70.2%
Estimate against measurement, compound 3: 18.8 percentage points above, and the stated range ends above it.
By their numbers in this assay, from the lowest: compound 3; then compounds 2 and 1 (each within the scatter of the next).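

In this assay, fluoro in place of hydrogen on the benzoyl ring is not a neutral change: it gives a number 18 percentage points lower from compound 2 to compound 3 (beyond the scatter). With the 4-fluorophenyl kept, dimethylamino in place of methyl on an aromatic carbon gives a number 21.3 percentage points lower from compound 1 to compound 3 (beyond the scatter). Both single changes leading to compound 3 therefore lower inhibition, which the earlier pair could not show, since compound 1 and compound 2 differ in two places. The compounds shown leave open whether chloro or methoxy in place of the fluoro would lower inhibition in the same way. Nothing given here accounts for either step.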